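The source may report more compounds than this note shows. Statements on the series, on what has been measured and on what is new or still open speak of the compounds shown alone.

Measured so far in a functional assay on HT-29 cells (Homo sapiens) for cytotoxicity, read by MTT assay, with a stated time of 72 h; a higher number here means a weaker inhibitor, a lower number a stronger inhibitor:
compound 1, `O=C(Nc1nc2ccccc2s1)c1cn(-c2ccccc2)nc1-c1ccc(F)cc1`: 9060 nM
compound 2, `O=C(Nc1nc2ccccc2s1)c1cn(-c2ccccc2)nc1-c1ccc(Cl)cc1`: 13700 nM

Of the two numbers, compound 2 gives the higher, but the step of a 1.5-fold higher number from compound 1 to compound 2 (0.18 log units; within the scatter) lies within the scatter, so no order between the two is claimed. Compound 3, `COc1ccc(-c2nn(-c3ccccc3)cc2C(=O)Nc2nc3ccccc3s2)cc1`, has not yet been measured. The change from compound 2 to compound 3 is methoxy in place of chloro on an aromatic carbon. Among the measured compounds shown here, only one measured step touches this position: the exchange of one halogen for another, a 1.5-fold higher number from compound 1 to compound 2 (0.18 log units; within the scatter), which did not move the number beyond the scatter. For the measured compounds named here, no measured pair carries a methoxy group at this place, so nothing shows whether a methoxy behaves like the two halogens already seen. Going by the values given here, on the sole evidence that exchanging the group here left the number essentially unchanged, the expected step is a 1.2-fold lower number from compound 2 to compound 3 (0.10 log units; within the scatter), in neither direction beyond the scatter. Compound 3 is therefore estimated at 11000 nM, with a range from 4000 nM to 30000 nM.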

Compound 3, half-maximal inhibitory concentration: 10500 nM
For compound 3 the middle estimate is 1.0-fold (0.02 log units) above the measured one; the measured number falls inside the stated range.
By their numbers in this assay, from the lowest: compounds 1, 3 and 2 (each within the scatter of the next).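

In this assay, methoxy in place of chloro gives (a 1.3-fold lower number from compound 2 to compound 3 (0.12 log units; within the scatter)), and methoxy in place of fluoro gives (a 1.2-fold higher number from compound 1 to compound 3 (0.06 log units; within the scatter)), so neither exchange moves the number beyond the scatter. Until now this position had been probed only by swapping one halogen for another; it now also accommodates a group of a different kind, since 4-methoxyphenyl brings two heavy atoms and one hydrogen-bond acceptor where 4-chlorophenyl brings one heavy atom and no acceptor, with no readable change in the number. Nothing available bears on the reason for this flat response.

From the compounds shown here alone, whether the position stays this flat for all groups remains open: an amine, a carboxylic acid or a longer chain such as butoxy in place of methoxy could still move the number beyond the scatter, and the same question applies to a bare hydrogen at this place. The three compounds also share everything else in the core of compound 1, so they leave open whether a change at any other place would matter more in this assay than the exchanges seen here.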